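Trading a non-aromatic amide group for an aromatic one

The source may hold more compounds than are shown below. What is called first, only, known or untested is meant among the compounds shown, and "the series" means these compounds.

In a functional assay on BaF3 cells (Mus musculus) for antiproliferative activity, read by CCK-8 assay and cell counting, with a stated time of 76 h (a lower number here means a stronger inhibitor, a higher number a weaker inhibitor), compound 1 `COc1cc2nccc(Oc3ccc(Nc4nn(C)cc4C(=O)NC4CCCCCCC4)cc3)c2cc1C(N)=O` gives 3210 nM, and compound 2 `COc1cc2nccc(Oc3ccc(Nc4nn(C)cc4C(=O)N4CCCC5CCCCC54)cc3)c2cc1C(N)=O` gives 4330 nM, so compound 2 stands level with compound 1 within the scatter. Compound 3 `COc1cc2nccc(Oc3ccc(Nc4nn(C)cc4C(=O)Nc4cccc(F)c4)cc3)c2cc1C(N)=O` differs from compound 2 by a group of 8 heavy atoms (6 carbon, 1 nitrogen, 1 fluorine; one six-membered aromatic ring of carbon only) in place of a group of 10 heavy atoms (9 carbon, 1 nitrogen; one six-membered non-aromatic ring of carbon only, one six-membered non-aromatic ring with 1 hetero atom), on a carbonyl carbon. Going by the values given here, the only measured step, a 1.3-fold higher number from compound 1 to compound 2 (0.13 log units; within the scatter), exchanges one non-aromatic ring group for another and tests no aromatic ring, so it is a weak guide. It points to no clear change, with wide uncertainty. The expected change is a 1.7-fold lower number from compound 2 to compound 3 (0.24 log units; within the scatter). For compound 3 the estimated value is 2500 nM, with an expected range from 400 nM to 8000 nM.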

Compound 3, half-maximal inhibitory concentration: 4480 nM
Compound 3: the middle estimate sits 1.8-fold (0.25 log units) below what was measured; measured number inside the range.
By their numbers in this assay, from the lowest: compounds 1, 2 and 3 (each within the scatter of the next).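

In this assay the aromatic (3-fluorophenyl)amino group on this carbonyl carbon gives a 1.0-fold higher number from compound 2 to compound 3 (0.01 log units; within the scatter) and, with 3-fluorophenyl in place of cyclooctyl on the amide-type nitrogen, a 1.4-fold higher number from compound 1 to compound 3 (0.14 log units; within the scatter). Among these three compounds, then, an aromatic ring here reads the same as either non-aromatic ring group, and swapping ring type at this place shows no measurable effect. Nothing available explains this flat result. Still open, going by these compounds, is whether a phenyl ring carrying an amine or a carboxylic acid, or a small cyclopropyl group, would move the number beyond the scatter.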